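The source may hold more compounds than are shown below. What is called first, only, known or untested is meant among the compounds shown, and "the series" means these compounds.

In a physicochemical assay for pharmacokinetics, at pH 4 (a lower number here means that the compound disappears faster, a higher number that the compound lasts longer), compound 1 `Cc1ccc(Oc2ccc(C(=O)NCc3ccccc3)cc2)cc1` gives > 1000 h, which is a limit of the assay and not a number. Going by these compounds, compound 2 `Cc1ccc(Oc2ccc(C(=O)NCC3CCCCC3)cc2)cc1` gives > 1000 h, and this too is a limit, so its true position on the scale stays unknown.

Compound 3 `COc1cccc(CNC(=O)c2ccc(Oc3ccc(C)cc3)cc2)c1` has not yet been measured. It carries 3-methoxyphenyl in place of cyclohexyl on a saturated chain carbon bound to an amide-type nitrogen, and the count of that change is 3-methoxyphenyl in place of cyclohexyl on a saturated chain carbon bound to an amide-type nitrogen.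

Among the compounds with values here, only one measured step bears on this place in the molecule: a step that the two limits leave unreadable from compound 1 to compound 2. That step has no readable size, so it offers no number to carry over to the new group. What it does offer is a plain observation, since both compounds sit at the same limit.

Because of the limit of > 1000 h in this assay, at which 2 of the 2 values shown sit, no step beyond the usual scatter is expected in this assay, and no direction can be named. The expected change is a number no higher from compound 2 to compound 3 (the limit leaves the size open).

For compound 3 the estimate is 1000 h, with an expected range from 500 h to 2000 h.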

Compound 3, half-life: > 1000 h
Compound 3 ended at the assay's limit; the forecaster's own chance of this, stated with the estimate: 90%; the middle value sits exactly at the limit.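

In this assay compound 3 gives > 1000 h, which is a limit of the assay and not a number. Within the data shown here, no step among compound 1, compound 2 and compound 3 can be read, because all three stop at the same point: the limit of > 1000 h in this assay, at which 3 of the 3 values shown sit. The compounds shown leave open how long each one truly lasts and whether the groups differ at all in this measure.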